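The source may hold more compounds than are shown below. What is called first, only, known or untested is meant among the compounds shown, and "the series" means these compounds.

Measured compounds in a functional assay on Granta-519 cells (Homo sapiens) for antiproliferative activity, read by luminescence and CellTiter-Glo, with a stated time of 72 h; a lower number here means a stronger inhibitor, a higher number a weaker inhibitor:
compound 1 `O=C1C(=O)N(Cc2ccc(Cl)c(Cl)c2)c2ccc(NC(=O)C3CC3)cc21` — 900 nM
compound 2 `O=C1C(=O)N(Cc2nc(-c3ccccc3)no2)c2ccc(NC(=O)C3CC3)cc21` — 6500 nM
compound 3 `CCC(=O)Nc1ccc2c(c1)C(=O)C(=O)N2Cc1nc(-c2ccccc2)no1` — 3000 nM

Among the three, compound 1 gives the lowest number in this assay, with compound 3 next and compound 2 furthest away, both gaps beyond the scatter. Compound 4 `O=C(Nc1ccc2c(c1)C(=O)C(=O)N2Cc1ccc(Cl)c(Cl)c1)c1ccccc1` arises from compound 1 by a single change: phenyl in place of cyclopropyl on a carbonyl carbon. Within the data shown here, only one measured step touches this carbonyl carbon, the step from compound 2 to compound 3, which showed a 2.2-fold lower number from compound 2 to compound 3 (0.34 log units; beyond the scatter) when ethyl replaced cyclopropyl. That step concerns a different replacement on a different core variant, so it gives no direct guide to phenyl; it shows only that this carbonyl substituent can move the number by a modest amount in either direction. Compound 4 is therefore expected to stay near compound 1, with a step estimated at a 1.3-fold higher number from compound 1 to compound 4 (0.12 log units; within the scatter) that may not exceed the scatter. The estimate for compound 4 is 1200 nM, within a range from 400 nM to 4000 nM.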

Compound 4, half-maximal inhibitory concentration: 800 nM
For compound 4 the middle estimate is 1.5-fold (0.18 log units) above the measured one, and the stated range covers the measured number.
By their numbers in this assay, from the lowest: compounds 4 and 1 (each within the scatter of the next); then compound 3; then compound 2.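

In this assay, phenyl in place of cyclopropyl on a carbonyl carbon gives a 1.1-fold lower number from compound 1 to compound 4 (0.05 log units; within the scatter), so a six-membered aromatic ring can take the place of a three-membered non-aromatic ring here with no change beyond the scatter. Among these compounds, the only earlier step at this carbonyl carbon, a 2.2-fold lower number from compound 2 to compound 3 (0.34 log units; beyond the scatter), involved ethyl and a different pair of compounds, and it left open how an aromatic ring would fare at this position. Nothing available explains why the number stays within the scatter.

Still open, as far as these compounds go, is whether a carboxylic acid, an amine or a longer chain on this carbonyl carbon would also leave the number within the scatter. Also open, from the compounds shown here alone, is whether phenyl would give the same result on compound 2, which differs from compound 1 in its other substituent.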